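A few compounds are considered here, and "the series" means these few. Any claim that something is new, unique, unknown or untested is made for them only; others in the source may bear on it.

The three measured compounds share one structural change, a methoxy entering in place of hydrogen, but on two different cores. Compound 1 `COc1cc(OC)cc(-c2nc3cc(F)ccc3o2)c1` and compound 2 `COc1cc(-c2nc3cc(F)ccc3o2)cc(OC)c1OC` were both tested in a functional assay on MCF7 cells (Homo sapiens) for inhibition; a higher number here means a weaker inhibitor, a lower number a stronger inhibitor: compound 1 gives 45400 nM, and compound 2 gives 16000 nM. The change between them, (methoxy in place of hydrogen on an aromatic carbon), produced a 2.8-fold lower number from compound 1 to compound 2 (0.45 log units; beyond the scatter).

Compound 3 `COc1ccc(-c2nc3ccc(F)cc3o2)cc1` is built on another core; the difference between the cores of compound 1 and compound 3 is not broken down here. In this assay compound 3 gives 41000 nM, a number that sits within the scatter of that of compound 1.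

Compound 4 `COc1ccc(-c2nc3ccc(F)cc3o2)c(OC)c1` has not yet been measured. It differs from compound 3 by methoxy in place of hydrogen on an aromatic carbon. Going by the values given here, this is the same kind of change as the one between compound 1 and compound 2, not the same one: there the entering methoxy was ortho to two methoxy groups and para to a large group, here it is ortho to a large group and meta to a methoxy group. Resting only on that single earlier step, compound 4 is expected to show a 1.6-fold lower number from compound 3 to compound 4 (0.21 log units; within the scatter) in this assay, with wide uncertainty given the different surroundings. The estimate for compound 4 is 25000 nM, in a range from 8000 nM to 80000 nM.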

Compound 4, half-maximal inhibitory concentration: 69900 nM
Beside the measured number, compound 4's estimate is 2.8-fold (0.45 log units) below it; low and high end bracket the measured number.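

In this assay the entering methoxy gave a 1.7-fold higher number from compound 3 to compound 4 (0.23 log units; within the scatter), a step that cannot be told apart from repeat measurement, whereas the same kind of change on the other core lay beyond the scatter. Set side by side, the two steps show that the change did not carry over from one core to the other with the same size: the same change on two cores in this assay, a 2.8-fold lower number (0.45 log units; beyond the scatter) from compound 1 to compound 2 and a 1.7-fold higher number (0.23 log units; within the scatter) from compound 3 to compound 4, 4.8-fold (0.68 log units) apart, beyond the scatter of two such steps. This does not show whether the core or the surroundings of the methoxy, here ortho to a large group and meta to a methoxy group, account for the gap, and with one step on each core it gives no rule for any further core.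

The compounds shown leave open how an amine, a carboxylic acid or a longer chain would read in this assay in place of the entering methoxy. As far as these compounds go, it is also open how methoxy would read at other places on the same ring of compound 3.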